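Swapping the halopyridine carbonyl on a benzyloxy pyrazoline

The compounds below may be only part of what the source reports. "The series", "measured", "known", "first", "only" and "open" are said of these compounds alone.

Of the compounds shown here, three share a core and have been tested in a functional assay on WM 266-4 cells (Homo sapiens) for antiproliferative activity, read by MTT assay, with a stated time of 24 h; a higher number here means a weaker inhibitor of growth, a lower number a stronger inhibitor of growth. Compound 1 `COc1ccc(C2=NN(C(=O)c3cccnc3Cl)C(c3ccc(Cl)cc3)C2)cc1` gives 780 nM. Compound 2 `COc1ccc(C2=NN(C(=O)c3cncc(Br)c3)C(c3ccc(OCc4ccccc4)cc3)C2)cc1` gives 6240 nM. Compound 3 `O=C(c1cncc(Br)c1)N1N=C(c2ccc(Cl)cc2)CC1c1ccc(OCc2ccccc2)cc1` gives 8130 nM, the highest of the three numbers, though the step of a 1.3-fold higher number from compound 2 to compound 3 (0.11 log units; within the scatter) lies within the scatter, so compound 3 and compound 2 cannot be ordered; only compound 1 sits clearly apart. Compound 4 `O=C(c1cccnc1Cl)N1N=C(c2ccc(Cl)cc2)CC1c1ccc(OCc2ccccc2)cc1` has not been measured. It differs from compound 3 by 2-chloropyridin-3-yl in place of 5-bromopyridin-3-yl on a carbonyl carbon. Within the data shown here, no measured step bears directly on this change: the one measured step concerns the methoxy-to-chloro swap, not the pyridine. Compound 1 carries the same 2-chloropyridin-3-yl carbonyl and gives 780 nM, but it also differs from compound 4 in the benzyloxy group, so it offers only a loose hint that the number may fall. A modest drop is therefore expected, with wide uncertainty: the step of a 2.0-fold lower number from compound 3 to compound 4 (0.31 log units; beyond the scatter) is an estimate. Compound 4 is expected to give about 4000 nM, between 1000 nM and 12000 nM.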

Compound 4, concentration for 50% growth inhibition: 7710 nM
Beside the measured number, compound 4's estimate is 1.9-fold (0.28 log units) below it, and the stated range covers the measured number.
By their numbers in this assay, from the lowest: compound 1; then compounds 2, 4 and 3 (each within the scatter of the next).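

In this assay, exchanging 5-bromopyridin-3-yl for 2-chloropyridin-3-yl on a carbonyl carbon gives a 1.1-fold lower number from compound 3 to compound 4 (0.02 log units; within the scatter) and so leaves the two compounds indistinguishable. Among these compounds, this is the first direct reading at this position, where the halogen and its place on the pyridine ring both differ, and neither combination can be ranked above the other. The earlier single-place step, a 1.3-fold higher number from compound 2 to compound 3 (0.11 log units; within the scatter), concerned only the methoxy-to-chloro swap, so the two changes made around compound 3 have now both stayed within the scatter. No measurement shown explains why these two pyridine groups read alike.

From the compounds shown here alone, whether a plain phenyl, or a pyridine carrying an amine or a carboxylic acid, would read differently on this carbonyl carbon stays open. So does whether the same pyridine exchange would read alike with methoxy in place of chloro.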